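From 3-nitrophenyl to 2-hydroxyphenyl on the shared core

This account rests on a few compounds, and the source may have more. Where it says the series, first, only, none or still open, it means among the compounds named here.

Of the compounds shown here, two have been measured so far in a physicochemical assay for lipophilicity, measured as octanol-water partition; a higher number here means a more lipophilic compound, a lower number a more polar compound. Compound 1 `C/C(=N\NC(=O)COc1cccc2ccccc12)c1cccc([N+](=O)[O-])c1` gives 3.37 and compound 2 `COc1ccc(/C=N/NC(=O)COc2cccc3ccccc23)cc1OC` gives 3.51, which places the two within the scatter of each other. For the measured compounds named here, no measured pair differs in one place only, so this series offers no direct precedent for the change at hand.

Compound 3 `C/C(=N\NC(=O)COc1cccc2ccccc12)c1ccccc1O` carries 2-hydroxyphenyl in place of 3-nitrophenyl on a carbon with a double bond to nitrogen. Going by the values given here, the only guide is indirect: compound 2, at 3.51, has a different structure at that place and still stays within the scatter of compound 1. The expected step of a number 0.08 log units higher from compound 1 to compound 3 (within the scatter) does not go beyond the scatter, and no firm direction is expected. For compound 3 the estimated value is 3.45, with an expected range from 3 to 3.9.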

Compound 3, partition coefficient: 3.08
For compound 3 the middle estimate is 0.37 log units above the measured one, within the range that was stated.
By their numbers in this assay, from the lowest: compounds 3, 1 and 2 (each within the scatter of the next, the first and the last beyond it).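

In this assay, the first step read at one place in this series, 2-hydroxyphenyl in place of 3-nitrophenyl on a carbon with a double bond to nitrogen, gives a number 0.29 log units lower from compound 1 to compound 3 (within the scatter) and so stays inside the usual spread of repeat measurements. At this place, the exchange of 3-nitrophenyl, with 9 heavy atoms and 0 hydrogen-bond donors, for 2-hydroxyphenyl, with 7 heavy atoms and 1 hydrogen-bond donor, therefore produces no readable shift in the partition coefficient. No supporting evidence bears on this result.

Going by these compounds, whether a group such as an amine or a carboxylic acid at this place would move the number beyond the scatter remains open. A single step also cannot separate what the departing nitro group and the entering hydroxyl group each contribute.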